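From ethoxy to propoxy: tolerance on MDCK cells

The source may hold more compounds than are shown below. What is called first, only, known or untested is meant among the compounds shown, and "the series" means these compounds.

Compound 1 `Cc1ccc2[nH]c(=O)c(CN(Cc3ccc(O)cc3)Cc3ccc(C(C)(C)C)cc3)cc2c1` carries a free phenol. In a toxicity assay on MDCK cells (Canis lupus familiaris) for cytotoxicity, read by crystal violet staining, with a stated time of 48 h (a lower number here means that less compound is tolerated, a higher number that more compound is tolerated), compound 1 gives 4900 nM. Compound 2 `CCOc1ccc(CN(Cc2ccc(C(C)(C)C)cc2)Cc2cc3cc(C)ccc3[nH]c2=O)cc1` differs only by an ethyl on that phenolic oxygen. In this assay compound 2 reaches the limit of the assay, > 10000 nM, so no number is known for it. The change an at least 2.0-fold higher number from compound 1 to compound 2 (0.30 log units; that floor lies within the scatter) therefore rests on a value that sits at the limit (the limit of > 10000 nM in this assay, at which 1 of the 2 values shown sits), and its true size may be larger than the floor shown. Compound 3 `CCCOc1ccc(CN(Cc2ccc(C(C)(C)C)cc2)Cc2cc3cc(C)ccc3[nH]c2=O)cc1` lengthens the ether by one carbon: methyl in place of hydrogen on a saturated chain carbon, two bonds along the chain from an oxygen on an aromatic ring. Among the measured compounds shown here, only the step from compound 1 to compound 2 bears on this change; it ran toward more compound being tolerated, and compound 2 already stands at the top of the measurable range. A further lengthening of the same chain is expected to keep compound 3 at or beyond that limit, with the step that the limit leaves unreadable from compound 2 to compound 3 expected to be small. Compound 3 is estimated at 15000 nM, within 5000 nM to 50000 nM, and most likely reported only as a limit.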

Compound 3, half-maximal cytotoxic concentration: > 5000 nM
Compound 3: a limit, no number (the forecaster's own chance of this, stated with the estimate: 75%); the middle value does not contradict the limit.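

In this assay compound 3 gives > 5000 nM, which is a limit of the assay and not a number. Measured against the free phenol, the propyl ether yields only a floor, an at least 1.0-fold higher number from compound 1 to compound 3 (0.00 log units; that floor lies within the scatter), so this result alone does not separate the two compounds, and it adds no measured value for the longer ether. The one change at this position, methyl in place of hydrogen on a saturated chain carbon, two bonds along the chain from an oxygen on an aromatic ring, cannot be read, since neither end of it carries a number: the limit of > 5000 nM in this assay, at which 1 of the 3 values shown sits.

As far as these compounds go, the true values of compound 2 and compound 3 remain open, and with them whether going from ethoxy to propoxy alters tolerance at all or whether the propyl ether could fall short of the ethyl ether. Also open, from the compounds shown here alone, is how a butyl or a benzyl group in place of the propyl on that oxygen would read in this assay, and whether either would give a number rather than a limit.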